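Cyclopentyl for Butyl on a Hydroxamic-Free Anilide Series

The source may report more compounds than this note shows. Statements on the series, on what has been measured and on what is new or still open speak of the compounds shown alone.

Compound 1 `Nc1ccccc1NC(=O)c1ccc(COCNc2nc(Nc3ccccc3)c3ncn(C4CCCC4)c3n2)cc1` gives 75.2% in a functional assay on HCT-116 cells (Homo sapiens) for antiproliferative activity, read by CCK-8 assay, with a stated time of 72 h, tested at 2 uM; on this read-out lower numbers stand for a weaker effect and higher numbers for a stronger effect at the one concentration tested.
Compound 2 `CCCCn1cnc2c(Nc3ccccc3)nc(NCOCc3ccc(/C=C/C(=O)Nc4ccccc4N)cc3)nc21` gives 6.58% in this assay.
Compound 3 `CCCCn1cnc2c(Nc3ccccc3)nc(NCOCc3ccc(C(=O)Nc4ccccc4N)cc3)nc21` gives 72.9% in this assay.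

Of the compounds shown here, three have been measured and one, compound 4 `Nc1ccccc1NC(=O)/C=C/c1ccc(COCNc2nc(Nc3ccccc3)c3ncn(C4CCCC4)c3n2)cc1`, has not. The measured set shows two kinds of change. The first is cyclopentyl in place of butyl on an aromatic nitrogen, which made a step of a number 2.3 percentage points higher from compound 3 to compound 1 (within the scatter). The second is the difference between the cores of compound 3 and compound 2, (2-((2-aminophenyl)carbamoyl)ethenyl in place of (2-aminophenyl)carbamoyl on an aromatic carbon), which made a step of a number 66.3 percentage points higher from compound 2 to compound 3 (beyond the scatter) when read from compound 2 to compound 3. Compound 2 stands lowest of the three numbers, and its distance to both other compounds is beyond the scatter.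

Compound 4 is related to compound 2 by cyclopentyl in place of butyl on an aromatic nitrogen. This is the same change that takes compound 3 to compound 1, at the same place on the core, and there it made a step of a number 2.3 percentage points higher from compound 3 to compound 1 (within the scatter), a step within the scatter. Compound 4 also shares with compound 2 the 2-((2-aminophenyl)carbamoyl)ethenyl group that goes with the low number of compound 2, 6.58%.

On this basis the step from compound 2 to compound 4 in this assay is expected to be small, about a number 2.4 percentage points higher from compound 2 to compound 4 (within the scatter), because the same change gave a number 2.3 percentage points higher from compound 3 to compound 1 (within the scatter) between compound 3 and compound 1. Compound 4 is therefore estimated at 9%, with a range from 0% to 25%.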

Compound 4, a percentage reported as inhibition, at one concentration (the size of the read-out at that concentration, not a potency): 10.5%
Compound 4: the middle estimate sits 1.5 percentage points below what was measured; measured number inside the range.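

In this assay, cyclopentyl in place of butyl on an aromatic nitrogen gave a number 3.9 percentage points higher from compound 2 to compound 4 (within the scatter), so on the core carrying the ethenyl group this change again separated the compounds by no more than the scatter, and the step carried over from the other core: the same change on two cores in this assay, a number 2.3 percentage points higher (within the scatter) from compound 3 to compound 1 and a number 3.9 percentage points higher (within the scatter) from compound 2 to compound 4, 1.6 percentage points apart, within the scatter of two such steps. The larger change, 2-((2-aminophenyl)carbamoyl)ethenyl in place of (2-aminophenyl)carbamoyl on an aromatic carbon, gave a number 64.7 percentage points lower from compound 1 to compound 4 (beyond the scatter), and with a cyclopentyl or a butyl group on the aromatic nitrogen it made a step of much the same size: the same change on two cores in this assay, a number 66.3 percentage points higher (beyond the scatter) from compound 2 to compound 3 and a number 64.7 percentage points higher (beyond the scatter) from compound 4 to compound 1, 1.6 percentage points apart, within the scatter of two such steps. This shows that within these four compounds each change kept its step whichever form the other place took, but it does not show that cyclopentyl and butyl differ, nor that the agreement would hold at another concentration, in another cell line or on any further core.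

The compounds shown leave open how a longer chain, a cyclohexyl ring or a chain ending in an amine would behave on the aromatic nitrogen. They also leave open what a saturated two-carbon chain in place of the ethenyl link, or a hydroxamic acid in place of the 2-aminophenyl amide, would do to the read-out.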